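The compounds below may be only part of what the source reports. "The series", "measured", "known", "first", "only" and "open" are said of these compounds alone.

Measured so far in an assay on microsomes from intestine for inhibition of acyl-CoA:cholesterol acyltransferase (Oryctolagus cuniculus); a lower number here means a stronger inhibitor, a higher number a weaker inhibitor:
compound 1 `Cc1cc(C)c(NC(=O)N(Cc2cccc(-c3csc(C)n3)c2)C2CCCCCC2)c(C)c1`: 180 nM
compound 2 `Cc1cc(C)c(NC(=O)N(Cc2cccc(-c3nnn(C)n3)c2)C2CCCCCC2)c(C)c1`: 100 nM
compound 3 `Cc1cc(C)c(NC(=O)N(Cc2cccc(-c3cc[nH]n3)c2)C2CCCCCC2)c(C)c1`: 65 nM

Compound 3 stands at the low end of the three numbers: a 1.5-fold lower number from compound 2 to compound 3 (0.19 log units; within the scatter) lies within the scatter, whereas a 2.8-fold lower number from compound 1 to compound 3 (0.44 log units; beyond the scatter) lies beyond it. Compound 4 `Cc1cc(C)c(NC(=O)N(Cc2cccc(-c3ccnn3C)c2)C2CCCCCC2)c(C)c1` carries 1-methyl-1H-pyrazol-5-yl in place of 1H-pyrazol-3-yl on an aromatic carbon. Going by the values given here, the steps that bear on this are the other azole swaps on the same aromatic carbon, a 1.8-fold lower number from compound 1 to compound 2 (0.26 log units; within the scatter) and a 1.5-fold lower number from compound 2 to compound 3 (0.19 log units; within the scatter); in particular the methyl-bearing azole of compound 2 and the unsubstituted pyrazole of compound 3 sit within the scatter of each other. For compound 4 the step is therefore expected to be small, a 1.4-fold higher number from compound 3 to compound 4 (0.14 log units; within the scatter), if anything toward a slightly higher number. Compound 4 is estimated at 90 nM, with a range from 45 nM to 180 nM.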

Compound 4, half-maximal inhibitory concentration: 35 nM
Compound 4: middle estimate off by 2.6-fold (0.41 log units), on the high side; the measured number lies below the stated range.
By their numbers in this assay, from the lowest: compounds 4, 3, 2 and 1 (each within the scatter of the next, the first and the last beyond it).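

In this assay, a ring without a hydrogen-bond donor is accepted on this aromatic carbon: a 1.9-fold lower number from compound 3 to compound 4 (0.27 log units; within the scatter). The choice of methyl-bearing azole does register here, with a 2.9-fold lower number from compound 2 to compound 4 (0.46 log units; beyond the scatter) and a 5.1-fold lower number from compound 1 to compound 4 (0.71 log units; beyond the scatter), so the position separates these rings by more than the scatter. No measured evidence accounts for these differences.

The step from compound 3 to compound 4 adds the methyl and moves the ring attachment together, so neither change can be read alone. From the compounds shown here alone, how 1-methyl-1H-pyrazol-3-yl, or an amine or carboxylic acid on the azole, would behave stays open.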